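Anilinoquinone series on the shared core: one halogen swap

The source may hold more compounds than are shown below. What is called first, only, known or untested is meant among the compounds shown, and "the series" means these compounds.

Of the compounds shown here, two have been measured in a functional assay on ECa-109 cells for inhibition, with ECa-109 cell line (Homo sapiens) as the target, read by sulforhodamine B assay; on this read-out higher numbers stand for weaker inhibition and lower numbers for stronger inhibition. Compound 1 `O=C1C(Nc2ccc(Br)cc2)=CC(=O)c2c1nc1n2[C@H]2OC[C@@H](O)[C@H]2OC1` gives 1980 nM in this assay. Compound 2 `Cc1ccc(NC2=CC(=O)c3nc4n(c3C2=O)[C@H]2OC[C@@H](O)[C@H]2OC4)cc1C` gives 2820 nM in this assay. Compound 1 holds the lower of the two numbers, but the gap to compound 2 falls within the scatter, so the two cannot be told apart on what is shown, and no step between measured compounds stands in the record.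

Compound 3 `O=C1C(Nc2cccc(Cl)c2)=CC(=O)c2c1nc1n2[C@H]2OC[C@@H](O)[C@H]2OC1` has not yet been measured. It differs from compound 1 in one place: 3-chlorophenyl in place of 4-bromophenyl on an amine nitrogen. Both the group that leaves and the group that enters are a halogen on a phenyl ring carried by the same amine nitrogen, so the change is a small one on the outer part of the molecule.

For the measured compounds named here, with only two measured compounds, and those within the scatter of each other, no trend is available to lean on. The expected step from compound 1 to compound 3 is a 1.3-fold higher number from compound 1 to compound 3 (0.10 log units; within the scatter), which is to say no movement beyond the scatter in either direction. Compound 3 is therefore estimated at 2500 nM in this assay, with a likely range from 1000 nM to 6300 nM.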

Compound 3, half-maximal inhibitory concentration: 3080 nM
Beside the measured number, compound 3's estimate is 1.2-fold (0.09 log units) below it; measured number inside the range.
By their numbers in this assay, from the lowest: compounds 1, 2 and 3 (each within the scatter of the next).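

In this assay, the exchange of 4-bromophenyl for 3-chlorophenyl on the amine nitrogen gives a 1.6-fold higher number from compound 1 to compound 3 (0.19 log units; within the scatter) as the first step read at this position of the series. At this position, then, the halogen and its place on the phenyl ring can differ together without a shift that can be told from the scatter, though this rests on a single pair and supports no wider pattern. No measured property of these groups is available to account for the result.

The two differences in this pair are not separated, as no compound shown differs from compound 1 or compound 3 in the halogen alone or in its place on the ring alone. Also open, going by these compounds, is whether a phenyl without a halogen on the same amine nitrogen, or a phenyl carrying a carboxylic acid or an amine, would give a step beyond the scatter in this assay on the shared core.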